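This account rests on a few compounds, and the source may have more. Where it says the series, first, only, none or still open, it means among the compounds named here.

The compounds measured so far, with their numbers in a functional assay on A-375 cells (Homo sapiens) for antiproliferative activity, read by CCK-8 assay, with a stated time of 72 h, tested at 8 uM; on this read-out lower numbers stand for a weaker effect and higher numbers for a stronger effect at the one concentration tested:

Compound 1 `CN(Cc1cccnc1)C(=S)SCc1ccc(C(=O)Nc2ccccc2N)cc1`: 83.8%
Compound 2 `Nc1ccccc1NC(=O)c1ccc(CSC(=S)N2CCN(c3ccccc3F)CC2)cc1`: 79.5%
Compound 3 `Nc1ccccc1NC(=O)c1ccc(CSC(=S)N(Cc2ccccc2)Cc2ccccc2)cc1`: 32.5%

Compound 1 stands highest of the three numbers in this assay. Compound 2 gives 79.5%, which lies within the scatter of compound 1, so the two cannot be told apart. Compound 3 gives 32.5%, well beyond the scatter below compound 1. Among the compounds with values here, no pair of these three differs in a single place, so no step is recorded between measured compounds.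

Compound 4 `Nc1ccccc1NC(=O)c1ccc(CSC(=S)N2CCc3ccccc32)cc1` has not yet been measured. It differs from compound 1 in one place: 2,3-dihydro-1H-indol-1-yl in place of methyl((pyridin-3-yl)methyl)amino on a thiocarbonyl carbon. The three measured compounds share the core and vary only in the group on the thiocarbonyl carbon; compound 3 is the one that falls off sharply, while compound 2 stays with compound 1. For compound 4 a step downward from compound 1 is expected, of modest size, a number 18.8 percentage points lower from compound 1 to compound 4 (beyond the scatter), that may or may not exceed the scatter. Compound 4 is therefore estimated at 65%, with a range from 35% to 88%.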

Compound 4, a percentage reported as inhibition, at one concentration (the size of the read-out at that concentration, not a potency): 85.4%
Compound 4: the middle estimate sits 20.4 percentage points below what was measured; the measured number falls inside the stated range.
By their numbers in this assay, from the lowest: compound 3; then compounds 2, 1 and 4 (each within the scatter of the next).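

In this assay, putting 2,3-dihydro-1H-indol-1-yl in place of methyl((pyridin-3-yl)methyl)amino on a thiocarbonyl carbon gives a number 1.6 percentage points higher from compound 1 to compound 4 (within the scatter), so the two groups cannot be told apart at the one concentration tested. The change removes the hetero atom from the six-membered aromatic ring, leaves a group with no hydrogen-bond acceptor and closes the nitrogen into a five-membered non-aromatic ring, yet the read-out stays level; for this pair, then, neither the pyridine nitrogen nor the open-chain amine is needed for an effect of this size. No measurement shown here accounts for why these two groups read alike.

Because each number comes from a single concentration, the compounds shown leave open whether compound 1 and compound 4 would also match in potency. They also leave open whether a small open-chain dimethylamino group or a morpholin-4-yl ring at this place would stay level with these two in this assay or fall away as far as compound 3 does at 32.5%.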